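A few compounds are considered here, and "the series" means these few. Any claim that something is new, unique, unknown or untested is made for them only; others in the source may bear on it.

Compound 1 `CCOC(=O)C1=C(C)NC(=O)NC1c1ccc(O)cc1`: 25.8 ug/mL
Compound 2 `CCOC(=O)C1=C(C)NC(=S)NC1c1ccc(OC)cc1`: 25.9 ug/mL

In a functional assay on 786-0 cells (Homo sapiens) for inhibition, read by sulforhodamine B assay, with a stated time of 48 h (on this read-out lower numbers stand for stronger inhibition of growth and higher numbers for weaker inhibition of growth), compound 2 gives 25.9 ug/mL, and compound 1 gives 25.8 ug/mL, a difference within the usual scatter, so the two cannot be ranked against each other. Compound 3 `CCOC(=O)C1=C(C)NC(=S)NC1c1ccc(O)cc1` differs from compound 2 by a single change: hydrogen in place of methyl on an oxygen on an aromatic ring. Going by the values given here, no pair of measured compounds shows this change on its own, so there is no measured step to lean on. The step of a 1.0-fold lower number from compound 2 to compound 3 (0.02 log units; within the scatter) in this assay is therefore expected to be none beyond the scatter. Compound 3 is estimated at 25 ug/mL in this assay, within a range from 11 ug/mL to 55 ug/mL.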

Compound 3, concentration for 50% growth inhibition: 27.5 ug/mL
Compound 3: the middle estimate sits 1.1-fold (0.04 log units) below what was measured; the measured number falls inside the stated range.
By their numbers in this assay, from the lowest: compounds 1, 2 and 3 (each within the scatter of the next).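

In this assay, going by these compounds alone, the change from methoxy to hydroxy gives a 1.1-fold higher number from compound 2 to compound 3 (0.03 log units; within the scatter) and is the first measured reading of this change on its own. At this position on the aromatic ring, the methyl on the oxygen can therefore be removed without a shift beyond the scatter, and compound 2 and compound 3 cannot be ranked. Nothing at hand explains this result. Still open, going by these compounds, is whether a longer chain on that oxygen, or an amine in place of the hydroxy, would shift the number beyond the scatter.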